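A few compounds are considered here, and "the series" means these few. Any claim that something is new, unique, unknown or untested is made for them only; others in the source may bear on it.

Among the compounds with values here, in a functional assay on MKN-45 cells (Homo sapiens) for antiproliferative activity, read by MTT assay, with a stated time of 72 h (a higher number here means a weaker inhibitor, a lower number a stronger inhibitor), compound 1 `COc1cc(CCc2ccccc2)cc(OC)c1O` gives 1040 nM as the lowest of the three numbers so far, and both steps away from it lie beyond the scatter. Compound 2 `COc1cc(CCc2ccc(F)cc2)cc(OC)c1O` stands at 10700 nM and compound 3 `COc1cc(CCc2cccc(F)c2)cc(OC)c1O` at 2970 nM in the same read-out. Compound 4 `COc1cc(CCc2ccccc2F)cc(OC)c1O` is not yet measured. It differs from compound 1 by fluoro in place of hydrogen on an aromatic carbon (fluoro in place of hydrogen on an aromatic carbon, ortho to a large group). The same kind of replacement has been measured twice, giving a modest step (a 2.9-fold higher number from compound 1 to compound 3 (0.46 log units; beyond the scatter)) and a large one (a 10-fold higher number from compound 1 to compound 2 (1.01 log units; beyond the scatter)), both to a higher number. Within the data shown here, on those two steps alone, a step in the same direction is expected for compound 4 in this assay with a size between modest and large, although no measured compound carries the fluoro where compound 4 does. The expected step is a 3.4-fold higher number from compound 1 to compound 4 (0.53 log units; beyond the scatter) as an estimate only. The expected value for compound 4 is 3500 nM within an estimated range of 1200 nM to 11000 nM at this stage.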

Compound 4, half-maximal inhibitory concentration: > 25000 nM
Compound 4: only a limit was reported; the forecaster's own chance of this, stated with the estimate: 2%; middle value at least 7.1-fold (0.85 log units) away from the limit.
By their numbers in this assay, from the lowest: compound 1; then compound 3; then compound 2. At a limit, above all of these: compound 4.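

In this assay, within the data shown here, fluoro in place of hydrogen on an aromatic carbon ortho to a large group gives an at least 24-fold higher number from compound 1 to compound 4 (1.38 log units; beyond the scatter), the first reading of this replacement at this position. For compound 4 the reported figure is a limit of the assay and not a number: the limit of > 25000 nM in this assay, at which 1 of the 4 values shown sits. Every fluoro placement shown now goes to a higher number, and this position sides with the large step of a 10-fold higher number from compound 1 to compound 2 (1.01 log units; beyond the scatter) rather than the modest one of a 2.9-fold higher number from compound 1 to compound 3 (0.46 log units; beyond the scatter).

From the compounds shown here alone, the actual size of the step to compound 4 stays open, with only its lower bound known. Also open is whether any other group at this position keeps the number of compound 1: a methyl, a methoxy, a chloro or an amine there lies outside the compounds shown, as does a longer chain in the linker.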